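The source may hold more compounds than are shown below. What is called first, only, known or untested is meant among the compounds shown, and "the series" means these compounds.

Compound 1: `Cc1ncnc2c1c(-c1cccs1)cn2[C@@H]1O[C@H](CO)[C@@H](O)[C@H]1O`, a functional assay on HCT-116 cells (Homo sapiens), read by MTT assay, with a stated time of 72 h; on this read-out higher numbers stand for weaker inhibition and lower numbers for stronger inhibition: > 20000 nM
Compound 2: `COc1ncnc2c1c(-c1ccoc1)cn2[C@@H]1O[C@H](CO)[C@@H](O)[C@H]1O`, this assay: 110 nM

In this assay compound 1 gives > 20000 nM, and this is a limit of the assay rather than a number (the limit of > 20000 nM in this assay, at which 1 of the 2 values shown sits). For the measured compounds named here, compound 2 gives 110 nM in this assay and so holds the only measured number here. Compound 1 and compound 2 differ in more than one place, so their two values show only that one of them reaches a number and the other does not.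

Compound 3 is `Cc1ncnc2c1c(-c1ccoc1)cn2[C@@H]1O[C@H](CO)[C@@H](O)[C@H]1O` and has not yet been measured. It differs from compound 2 by methyl in place of methoxy on an aromatic carbon. Going by the values given here, no measured pair covers this change alone. Compound 1, which also carries methyl at that place, gives > 20000 nM. On that basis compound 3 is expected to come out clearly weaker than compound 2, a step of a 27-fold higher number from compound 2 to compound 3 (1.44 log units; beyond the scatter), well beyond the usual scatter. Compound 3 is estimated at 3000 nM, with a range from 300 nM to 20000 nM, and a limit alone would not surprise.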

Compound 3, half-maximal inhibitory concentration: > 20000 nM
Compound 3 was reported as a limit; the forecaster's own chance of this, stated with the estimate: 35%; middle value at least 6.6-fold (0.82 log units) away from the limit.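

With the furan-3-yl group held fixed, changing methoxy to methyl on the aromatic carbon next to the ring nitrogen gives an at least 180-fold higher number from compound 2 to compound 3 (2.25 log units; beyond the scatter). For the compounds shown here, this is the first comparison in this assay that isolates a single change, and it shows that this one position can decide whether a compound reaches a measured number at all. With methyl in place, neither the furan-3-yl nor the thiophen-2-yl compound reaches a number, and the step from compound 1 to compound 3 cannot be read, as both values are the same limit: the limit of > 20000 nM in this assay, at which 2 of the 3 values shown sit.

The compounds shown leave open whether other groups at this position, such as an amine, a chlorine atom or the longer ethoxy chain, would behave like methoxy or like methyl. They also leave open how thiophen-2-yl behaves alongside methoxy.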